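A few compounds are considered here, and "the series" means these few. Any claim that something is new, unique, unknown or untested is made for them only; others in the source may bear on it.

Compound 1 `CN1CCC[C@@H]1Cn1nc(Cc2cccc(F)c2)c2ccccc2c1=O`: 398 nM. Compound 2 `O=c1c2ccccc2c(Cc2ccc(Cl)cc2)nn1C[C@H]1CCCN1CCCCCc1ccc(OCCCN2CCCCCC2)cc1`: 50.1 nM. Compound 3 `CN(C)CCCn1nc(Cc2ccc(Cl)cc2)c2ccccc2c1=O`: 316 nM.

In an assay for binding affinity to Alpha-1B adrenergic receptor (Homo sapiens) (on this read-out higher numbers stand for weaker inhibition and lower numbers for stronger inhibition), compound 1 gives the highest of the three numbers. Compound 3 lies nearest to it, a gap within the usual scatter, while compound 2 lies furthest, a gap beyond the scatter. Compound 4 `CN1CCC[C@@H]1Cn1nc(Cc2cccc(Cl)c2)c2ccccc2c1=O` differs from compound 1 in one place: chloro in place of fluoro on an aromatic carbon. Among the measured compounds shown here, no measured pair shows this change on its own, so the size of the step is not known from the measurements. Compound 3 also carries a chloro and gives 316 nM, close to compound 1, so the expected step is modest: a 1.4-fold lower number from compound 1 to compound 4 (0.15 log units; within the scatter), likely not beyond the scatter. Compound 4 is estimated at 280 nM, with a range from 100 nM to 800 nM.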

Compound 4, inhibition constant: 631 nM
The estimate for compound 4 lay 2.3-fold (0.35 log units) below the measured number; the measured number falls inside the stated range.
By their numbers in this assay, from the lowest: compound 2; then compounds 3, 1 and 4 (each within the scatter of the next).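

Among the compounds shown here, the pair compound 1 and compound 4 is the first to isolate a single change at this position, the 3-fluorobenzyl to 3-chlorobenzyl swap, and in this assay it gives a 1.6-fold higher number from compound 1 to compound 4 (0.20 log units; within the scatter). At this position on the core of compound 1, then, chloro and fluoro cannot be told apart in this assay. No supporting data bear on why the two behave alike.

The compounds shown leave open whether a methoxy, a trifluoromethyl or a nitrile at this position, or an unsubstituted phenyl, would give a number beyond the scatter.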